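From Isobutyl to 2-(Methylsulfanyl)ethyl on Compound 2

The source may report more compounds than this note shows. Statements on the series, on what has been measured and on what is new or still open speak of the compounds shown alone.

- Compound 1 `CC1=CCC[C@H]2[C@](C)(CC3=CC(=O)C(N4CCC[C@H]4C(=O)O)=CC3=O)[C@@H](C)CC[C@]12C`: 49200 nM
- Compound 2 `CC(C)C[C@H](NC1=CC(=O)C=C(C(C)(C)C)C1=O)C(=O)O`: 97900 nM

Both compounds were tested in a functional assay on A549 cells (Homo sapiens) for cytotoxicity, read by MTT assay, with a stated time of 72 h; on this read-out higher numbers stand for weaker inhibition and lower numbers for stronger inhibition. For the measured compounds named here, there, compound 2 gives 97900 nM, a number within the usual scatter of the one for compound 1 at 49200 nM, so the two cannot be told apart.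

Compound 3 `CSCC[C@H](NC1=CC(=O)C=C(C(C)(C)C)C1=O)C(=O)O` has yet to be measured in this assay. It differs from compound 2 in one place: (methylsulfanyl)methyl in place of isopropyl on a saturated chain carbon, two bonds along the chain from an amine nitrogen and a carbonyl carbon. Here (methylsulfanyl)methyl stands in place of isopropyl on a saturated chain carbon, two bonds along the chain from an amine nitrogen and a carbonyl carbon. Cut one bond further out, the same difference reads isobutyl to 2-(methylsulfanyl)ethyl.

Going by the values given here, no measured pair shows what this change does, so the expectation starts from compound 2 at 97900 nM. No step beyond the scatter is expected in either direction. The estimated size of the change is a 1.2-fold lower number from compound 2 to compound 3 (0.09 log units; within the scatter). For compound 3 the expected value is 80000 nM, with an estimated range of 35000 nM to 180000 nM.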

Compound 3, half-maximal inhibitory concentration: > 200000 nM
Compound 3 gave a limit, no number; the forecaster's own chance of this, stated with the estimate: 15%; at least 2.5-fold (0.39 log units) between middle value and limit.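

In this assay compound 3 gives > 200000 nM, which is a limit of the assay and not a number. The change from isobutyl to 2-(methylsulfanyl)ethyl amounts to an at least 2.0-fold higher number from compound 2 to compound 3 (0.31 log units; beyond the scatter), so this position does not accept the change without a loss, something neither earlier compound could show. Only the lower bound of this step is known, and its full size cannot be read from the result: the limit of > 200000 nM in this assay, at which 1 of the 3 values shown sits.

On these data alone, the sulfur atom and the loss of the branch go together in this change, and whether either alone carries the step stays open; an n-butyl group at this place would separate the two. The compounds shown also leave open how a chain ending in a hydroxyl group or an amine would read in this assay, and whether any group at this position gives stronger inhibition than the isobutyl of compound 2.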